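Trading pyridin-4-yl for methyl on a carbonyl carbon

This account rests on a few compounds, and the source may have more. Where it says the series, first, only, none or still open, it means among the compounds named here.

Of the compounds shown here, three have been tested so far in a functional assay on TSGH 9201 cells (Homo sapiens) for cytotoxicity (a higher number here means a weaker inhibitor, a lower number a stronger inhibitor), on a shared core. Compound 1 `COc1ccc(S(=O)(=O)N2CCc3cccc(NC(=O)c4cccs4)c32)cc1` gives 54 nM and compound 2 `COc1ccc(S(=O)(=O)N2CCc3cccc(NC(=O)c4ccc(F)cc4)c32)cc1` gives 100 nM while compound 3 `COc1ccc(S(=O)(=O)N2CCc3cccc(NC(=O)c4ccncc4)c32)cc1` has the lowest number (10.8 nM) and is the strongest of the three. Compound 4 `COc1ccc(S(=O)(=O)N2CCc3cccc(NC(C)=O)c32)cc1` has methyl in place of pyridin-4-yl on a carbonyl carbon. Among the compounds with values here, two measured steps bear on this: arriving at pyridin-4-yl from other rings gave a 5.0-fold lower number from compound 1 to compound 3 (0.70 log units; beyond the scatter) and a 9.3-fold lower number from compound 2 to compound 3 (0.97 log units; beyond the scatter) and both lie beyond the scatter. Within the data shown here, no measured step removes the ring entirely, so the size is uncertain. A higher number is expected, with an estimated step of a 28-fold higher number from compound 3 to compound 4 (1.44 log units; beyond the scatter) in size. Compound 4 is estimated at 300 nM (range 60 nM to 1500 nM).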

Compound 4, half-maximal inhibitory concentration: 103 nM
Compound 4: middle estimate off by 2.9-fold (0.46 log units), on the high side; the range from low to high includes it.
By their numbers in this assay, from the lowest: compound 3; then compounds 1, 2 and 4 (each within the scatter of the next).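

In this assay, a plain methyl on the carbonyl carbon shows a 1.0-fold higher number from compound 2 to compound 4 (0.01 log units; within the scatter) and a 1.9-fold higher number from compound 1 to compound 4 (0.28 log units; within the scatter), so among these compounds the 4-fluorophenyl and thiophen-2-yl rings offer no measurable gain over it. Compound 3 goes against that picture: only pyridin-4-yl stands apart, with a 9.5-fold higher number from compound 3 to compound 4 (0.98 log units; beyond the scatter) on its loss. Nothing measured here explains why.

From the compounds shown here alone, it remains open whether an unsubstituted phenyl on the same carbonyl carbon would behave like pyridin-4-yl or like the other rings. Going by these compounds, a longer chain such as propyl in place of methyl is equally open.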